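This account rests on a few compounds, and the source may have more. Where it says the series, first, only, none or still open, it means among the compounds named here.

Compound 1, `c1cncc(N2CC[C@H]3CN[C@H]3C2)c1`, gives 71 nM in a functional assay on HEK293 cells for agonist activity at Neuronal acetylcholine receptor; alpha4/beta2 (Homo sapiens), read by FLIPR (a higher number here means that more compound is needed for the effect, a lower number that less compound is needed), the lowest number of the three measured compounds. Its mirror image, compound 2, `c1cncc(N2CC[C@@H]3CN[C@@H]3C2)c1`, gives 330 nM in this assay, and a 4.6-fold higher number from compound 1 to compound 2 (0.67 log units; beyond the scatter); the step rests on (the fact that compounds 1 and 2 differ only in the configuration as drawn). Compound 3, `COc1cncc(N2CC[C@H]3CN[C@H]3C2)c1`, gives 130 nM, so a 1.8-fold higher number from compound 1 to compound 3 (0.26 log units; within the scatter).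

Compound 4, `COc1ccc(N2CC[C@H]3CN[C@H]3C2)cn1`, differs from compound 1 by methoxy in place of hydrogen on an aromatic carbon. Among the compounds with values here, the one measured step that bears on this change is the methoxy addition in compound 3, and a 1.8-fold higher number from compound 1 to compound 3 (0.26 log units; within the scatter) stayed within the scatter. A step of similar size is therefore expected here, leaning towards a slightly higher number: a 1.8-fold higher number from compound 1 to compound 4 (0.26 log units; within the scatter). Compound 4 is estimated at 130 nM in this assay, with a range of 50 nM to 400 nM.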

Compound 4, half-maximal effective concentration: 2200 nM
Beside the measured number, compound 4's estimate is 17-fold (1.23 log units) below it, outside the stated range (above it).
By their numbers in this assay, from the lowest: compounds 1 and 3 (each within the scatter of the next); then compound 2; then compound 4.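

Methoxy on the aromatic carbon next to the ring nitrogen costs far more in this assay than the earlier methoxy step suggested, giving a 31-fold higher number from compound 1 to compound 4 (1.49 log units; beyond the scatter) for this single change. Compound 3, with methoxy on a different aromatic carbon, gives 130 nM while compound 4 gives 2200 nM, so among these compounds the outcome of adding methoxy depends on its place on the ring. Nothing measured here bears on why this position behaves differently.

Still open, going by these compounds, is whether the loss belongs to methoxy itself or to any group at this carbon; a fluorine, a methyl or an amine in the same place would separate the two.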